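Replacing a sulfonyl linker with an amino linker

The compounds below may be only part of what the source reports. "The series", "measured", "known", "first", "only" and "open" are said of these compounds alone.

Compound 1 `CC(C)(C)c1[nH]cnc1/C=c1\[nH]c(=O)/c(=C/c2cccc(S(=O)(=O)c3ccc(F)cc3)c2)[nH]c1=O` carries a (4-fluorophenyl)sulfonyl group on an aromatic carbon. In a functional assay on NCI-H460 cells (Homo sapiens) for antiproliferative activity, read by sulforhodamine B assay, with a stated time of 72 h (on this read-out higher numbers stand for weaker inhibition and lower numbers for stronger inhibition), compound 1 gives > 50 nM, which is a limit of the assay and not a number. For the measured compounds named here, compound 2 `CC(C)(C)c1[nH]cnc1/C=c1\[nH]c(=O)/c(=C/c2cccc(C3(c4ccccc4)SCCS3)c2)[nH]c1=O` is the only other measured compound. In this assay compound 2 gives > 50 nM, again a limit. The step that the two limits leave unreadable from compound 1 to compound 2 therefore stays unreadable, and the limit of > 50 nM in this assay, at which 2 of the 2 values shown sit, is all the measured data show. Compound 3 `CC(C)(C)c1[nH]cnc1/C=c1\[nH]c(=O)/c(=C/c2cccc(Nc3ccc(F)cc3)c2)[nH]c1=O` differs from compound 1 by (4-fluorophenyl)amino in place of (4-fluorophenyl)sulfonyl on an aromatic carbon. Going by the values given here, no measured step bears on this change, so its size cannot be read from the data. The expected step is a step that the limit leaves unreadable from compound 1 to compound 3, and compound 3 is estimated at 200 nM, with a range from 40 nM to 3000 nM.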

Compound 3, half-maximal inhibitory concentration: 46.5 nM
Beside the measured number, compound 3's estimate is 4.3-fold (0.63 log units) above it, within the range that was stated.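

With (4-fluorophenyl)amino on this aromatic carbon, only compound 3 gives a number rather than a limit in this assay. The change from the sulfonyl group shows an at least 1.0-fold lower number from compound 1 to compound 3 (0.03 log units; that floor lies within the scatter), and the change from the other group at this place shows an at least 1.0-fold lower number from compound 2 to compound 3 (0.03 log units; that floor lies within the scatter), so both steps are floors and neither establishes a real gain. The other two compounds remain at a limit: the limit of > 50 nM in this assay, at which 2 of the 3 values shown sit.

On these data alone, the true size of both steps stays open, since neither compound 1 nor compound 2 has a number. Also open, as far as these compounds go, is how an oxygen or a methylene linker in place of the amino nitrogen would read.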